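Chloro on the core of a weak pair

This account rests on a few compounds, and the source may have more. Where it says the series, first, only, none or still open, it means among the compounds named here.

In a functional assay on HT-29 cells (Homo sapiens) (on this read-out lower numbers stand for stronger inhibition of growth and higher numbers for weaker inhibition of growth), compound 1 (`O=S(=O)(/C=C/c1ccc(Br)cc1)Cc1ccc(Nc2ncnc3ccccc23)cc1`) gives > 100000 nM and this value is a limit. Among the compounds with values here, compound 2 (`O=S(=O)(/C=C/c1ccc(F)cc1Cl)Cc1ccc(Nc2ncnc3ccccc23)cc1`) gives 100000 nM as the only number so far. Compound 3 (`O=S(=O)(/C=C/c1ccc(F)cc1Cl)Cc1ccc(Nc2ncnc3cc(Cl)ccc23)cc1`) differs from it by chloro in place of hydrogen on an aromatic carbon with chloro in place of hydrogen on an aromatic carbon. Within the data shown here, because of the limit of > 100000 nM in this assay, at which 1 of the 2 values shown sits, the one measured step (a number no higher from compound 1 to compound 2 (the limit leaves the size open)) has no readable size and offers little guide for this change. A small estimated move towards stronger inhibition of growth is expected in this assay (a 2.0-fold lower number from compound 2 to compound 3 (0.30 log units; within the scatter)). For compound 3 the estimate is 50000 nM (expected range 10000 nM to 100000 nM).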

Compound 3, concentration for 50% growth inhibition: > 100000 nM
Compound 3: no number, only a limit; the forecaster's own chance of this, stated with the estimate: 35%; at least 2.0-fold (0.30 log units) between middle value and limit.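

In this assay compound 3 gives > 100000 nM and this value is a limit, not a number. Chloro in place of hydrogen at this aromatic carbon, meta to a fused ring and para to a fused ring, gives a number no lower from compound 2 to compound 3 (the limit leaves the size open) and shows no readable gain in growth inhibition, and the size of the step cannot be read because of a limit: the limit of > 100000 nM in this assay, at which 2 of the 3 values shown sit.

Still open, from the compounds shown here alone, is whether an amine or a methoxy group at this carbon would give a value clear of the limit. Also open, going by these compounds, is how chloro here would act in a compound with a readable value.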